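The compounds below may be only part of what the source reports. "The series", "measured", "known", "first", "only" and "open" are said of these compounds alone.

Three congeners of one shared core have been measured in a functional assay on MDA-MB-231 cells (Homo sapiens) for antiproliferative activity, read by MTT assay; on this read-out higher numbers stand for weaker inhibition and lower numbers for stronger inhibition. Compound 1 `CCCCCCCCCCCCCCCc1cc(=O)c2c(O)cc(O)c(C)c2o1` gives 6790 nM. Compound 2 `CCCCCCCCCCCCCCCc1cc(=O)c2c(O)c(C)c(OCOC)c(C)c2o1` reaches only a limit of the assay, > 87000 nM; this value is a limit and not a number (the limit of > 87000 nM in this assay, at which 1 of the 3 values shown sits). Compound 3 `CCCCC/C=C\C/C=C\CCCCCCCc1cc(=O)c2c(O)cc(OCOC)c(C)c2o1` gives 16100 nM, which is the higher of the two numbers actually recorded, sitting above compound 1 by a gap that lies beyond the usual scatter.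

The step from compound 3 to compound 4 `CCCCCCCCCCCCCCCc1cc(=O)c2c(O)cc(OCOC)c(C)c2o1` changes only the side chain (octyl in place of deca-1,4-dien-1-yl on a saturated chain carbon, seven bonds along the chain from an aromatic carbon). For the measured compounds named here, no measured pair isolates this change, so its size cannot be read off directly. Compound 4 shares the methoxymethyl ether of compound 3 and the saturated chain of compound 1, and compound 1 gives 6790 nM while compound 3 gives 16100 nM. Compound 4 is therefore expected to land at 12000 nM, within a range of 5000 nM to 30000 nM, corresponding to an expected step of a 1.3-fold lower number from compound 3 to compound 4 (0.13 log units; within the scatter) in this assay, near or only modestly below the value of compound 3.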

Compound 4, half-maximal inhibitory concentration: > 87000 nM
Compound 4: no number, only a limit (the forecaster's own chance of this, stated with the estimate: 10%); at least 7.2-fold (0.86 log units) between middle value and limit.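

In this assay compound 4 gives > 87000 nM, which is a limit and not a number: the limit of > 87000 nM in this assay, at which 2 of the 4 values shown sit. With the methoxymethyl ether held fixed, octyl in place of deca-1,4-dien-1-yl on a saturated chain carbon, seven bonds along the chain from an aromatic carbon, gives an at least 5.4-fold higher number from compound 3 to compound 4 (0.73 log units; beyond the scatter), the first direct sign that this side chain matters on the shared core. With the saturated chain held fixed, methoxymethyl in place of hydrogen on an oxygen on an aromatic ring gives an at least 12-fold higher number from compound 1 to compound 4 (1.10 log units; beyond the scatter), while the step between the two limits cannot be read.

Going by these compounds, how far the true value of compound 4 lies past its limit stays open. On these data alone, it is also open whether a chain with a single double bond, or a methyl ether in place of the methoxymethyl ether, would give a measurable value.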